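The source may hold more compounds than are shown below. What is called first, only, known or untested is meant among the compounds shown, and "the series" means these compounds.

Measured compounds:
compound 1, `O=C(NN1CCOC1=O)c1[nH]c2ccc(Cl)cc2c1S(=O)(=O)c1ccccc1` — > 100 uM
compound 2, `Cc1cc(C)cc(S(=O)(=O)c2c(C(=O)NNC(C)C)[nH]c3ccc(Cl)cc23)c1` — > 100 uM
compound 3, `Cc1cc(C)cc(S(=O)(=O)c2c(C(=O)NNC3CCCCC3)[nH]c3ccc(Cl)cc23)c1` — > 100 uM

In a functional assay on cells (Lymphocyte, Homo sapiens) for cytotoxicity (a lower number here means that less compound is tolerated, a higher number that more compound is tolerated), compound 1 gives only a limit of the assay, > 100 uM. Compound 2 likewise gives only a limit, > 100 uM. Compound 3 too gives only a limit, > 100 uM. So compound 3 stands at the same limit as the other two compounds, as the limit of > 100 uM in this assay, at which 3 of the 3 values shown sit, summarises; none of the three is separated from another by a readable number.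

The next compound, compound 4, `Cc1cc(C)cc(S(=O)(=O)c2c(C(=O)NNC(=O)NN)[nH]c3ccc(Cl)cc23)c1`, differs from compound 3 in one place: aminocarbamoyl in place of cyclohexyl on an amine nitrogen. Among the measured compounds shown here, the only measured step that touches this amine nitrogen is a step that the two limits leave unreadable from compound 2 to compound 3, and the two limits leave its size unreadable. For the measured compounds named here, there is therefore no measured step that tells how this change moves the read-out of this assay.

With both neighbours at the limit, compound 4 is expected to sit there as well: an estimated step of a number no higher from compound 3 to compound 4 (the limit leaves the size open), that is none beyond the scatter. For compound 4 the expected value is 100 uM, within 50 uM to 300 uM.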

Compound 4, half-maximal toxic concentration: > 100 uM
Compound 4: a limit, no number; the forecaster's own chance of this, stated with the estimate: 80%; the middle value lies on the limit itself.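

Compound 4 gives only a limit, as do compound 2 and compound 3, so the steps among these three cannot be read: the limit of > 100 uM in this assay, at which 4 of the 4 values shown sit.

The compounds shown leave open what actual number each would give, and whether isopropyl, cyclohexyl or aminocarbamoyl on the amine nitrogen makes any difference to the read-out.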